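A methyl removed from compound 2: expectation for compound 3

The source may hold more compounds than are shown below. What is called first, only, known or untested is meant among the compounds shown, and "the series" means these compounds.

Compound 1 `O=C(O)c1cc(O)cc(NCc2ccc(O)c(O)c2)c1`: 108000 nM
Compound 2 `COc1cccc(NCc2ccc(O)c(O)c2)c1`: 185000 nM

Both numbers come from an assay on liver for inhibition of arginase-1 (Bos taurus), with a stated time of 60 min; a higher number here means a weaker inhibitor, a lower number a stronger inhibitor. Compound 2 carries the highest of the two numbers, yet its nearest neighbour, compound 1, sits only slightly lower, and that gap lies within the scatter, so no order between the two can be read. Within the data shown here, no pair of measured compounds differs in a single place, so no measured step is available. Compound 3 `Oc1cccc(NCc2ccc(O)c(O)c2)c1` differs from compound 2 in one place: hydrogen in place of methyl on an oxygen on an aromatic ring. Among the measured compounds shown here, with no comparable step measured, the size of the change in this assay is open; the expectation is a step no larger than the scatter, in either direction. On that basis compound 3 is expected at 150000 nM, with a range from 60000 nM to 400000 nM. That estimate means an expected step of a 1.2-fold lower number from compound 2 to compound 3 (0.09 log units; within the scatter).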

Compound 3, half-maximal inhibitory concentration: 83000 nM
Estimate against measurement, compound 3: 1.8-fold (0.26 log units) above, and the stated range covers the measured number.
By their numbers in this assay, from the lowest: compounds 3, 1 and 2 (each within the scatter of the next, the first and the last beyond it).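

In this assay, among these compounds, the exchange of methoxy for hydroxy gives the first single-place step at this oxygen on the aromatic ring: a 2.2-fold lower number from compound 2 to compound 3 (0.35 log units; beyond the scatter), modest but beyond the scatter, so the methyl is not without consequence here. The second comparison, hydrogen in place of carboxy on an aromatic carbon, gives a 1.3-fold lower number from compound 1 to compound 3 (0.11 log units; within the scatter), which lies within the scatter, so the carboxy shows no readable effect in this pair. Nothing on hand speaks to the cause of the methoxy to hydroxy step.

The compounds shown leave open whether an amine or a longer chain such as ethoxy in this place would read like hydroxy or like methoxy. They also leave open whether the methoxy to hydroxy step holds on a ring that also carries a carboxylic acid.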